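A few compounds are considered here, and "the series" means these few. Any claim that something is new, unique, unknown or untested is made for them only; others in the source may bear on it.

Measured so far, cytotoxicity read-out:
- compound 1, `COc1cccc(CNCCCNc2ccnc3cc(-c4ccc(C(F)(F)F)cc4)ccc23)c1O`: 2210 nM
- compound 2, `COc1ccc(Oc2ccc3c(NCCCNCc4ccco4)ccnc3c2)cc1`: 5300 nM

In an ADME assay on HepG2 cells (Homo sapiens) for cytotoxicity, read by luminescence, CellTiter-Glo and ATP content, with a stated time of 72 h (on this read-out lower numbers stand for an effect already at smaller amounts and higher numbers for an effect only at larger amounts of compound), compound 1 gives 2210 nM, the lower of the two numbers shown; compound 2 gives 5300 nM in this assay, a gap that lies beyond the usual scatter. Compound 3, `COc1cccc(CNCCCNc2ccnc3cc(Oc4ccccc4)ccc23)c1O`, is not yet measured. It differs from compound 1 in one place: phenoxy in place of 4-(trifluoromethyl)phenyl on an aromatic carbon. For the measured compounds named here, no measured pair shows this change, so the direction of the step is open. A small step, expected from compound 1 to compound 3 as a 1.6-fold higher number from compound 1 to compound 3 (0.20 log units; within the scatter) toward a higher number, is anticipated in this assay. Compound 3 is estimated at 3500 nM, with a range from 1200 nM to 10000 nM.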

Compound 3, half-maximal effective concentration: 6800 nM
Beside the measured number, compound 3's estimate is 1.9-fold (0.29 log units) below it; the range from low to high includes it.
By their numbers in this assay, from the lowest: compound 1; then compounds 2 and 3 (each within the scatter of the next).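

In this assay, for the compounds shown here, phenoxy in place of 4-(trifluoromethyl)phenyl on this aromatic carbon gives a 3.1-fold higher number from compound 1 to compound 3 (0.49 log units; beyond the scatter), the first one-place step. The read-out therefore responds to the group at this position, at least for this pair on the shared core. Nothing available gives a reason for the step.

The change removes trifluoromethyl and brings in the oxygen of phenoxy at once, so the two cannot be told apart here. A plain phenyl group at this position would separate them.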